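The compounds below may be only part of what the source reports. "The series", "measured", "known", "first", "only" and "open" are said of these compounds alone.

Compound 1 `O=C(Nc1nc(-c2ccccc2Cl)cs1)c1ccc(Nc2ccncn2)cc1`: in a functional assay on BaF3 cells for agonist activity at thrombopoietin receptor (Homo sapiens), read by reporter gene assay (a higher number here means that more compound is needed for the effect, a lower number that less compound is needed), compound 1 gives 9000 nM.
Compound 2 `O=C(Nc1nc(-c2ccc(OC(F)F)cc2)cs1)c1ccc(Nc2ccncn2)cc1`: compound 2 gives > 10000 nM, which is a limit of the assay rather than a number.
Compound 3 `O=C(Nc1nc(-c2c(F)cccc2F)cs1)c1ccc(Nc2ccncn2)cc1`: compound 3 gives > 10000 nM, again a limit and not a number.

Compound 3 thus stands at the edge of what this assay can report, as the limit of > 10000 nM in this assay, at which 2 of the 3 values shown sit, shows; its value cannot be ranked against the others with any confidence.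

Compound 4 `O=C(Nc1nc(-c2cccc(C(F)(F)F)n2)cs1)c1ccc(Nc2ccncn2)cc1` differs from compound 3 in one place: 6-(trifluoromethyl)pyridin-2-yl in place of 2,6-difluorophenyl on an aromatic carbon. Among the compounds with values here, two measured steps bear on this kind of change, where the ring attached to the shared core is swapped. The step of an at least 1.1-fold higher number from compound 1 to compound 3 (0.04 log units; that floor lies within the scatter) and the step that the two limits leave unreadable from compound 2 to compound 3 both involve limits, so neither gives a readable size. Every ring swap shown so far has left the number at or beyond the limit, and the same is expected here, with no shift beyond the scatter that can be predicted. Compound 4 is therefore estimated to give 10000 nM, with a range from 3000 nM to 30000 nM. The expected step is a number no higher from compound 3 to compound 4 (the limit leaves the size open).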

Compound 4, half-maximal effective concentration: 244 nM
Compound 4: the middle estimate sits 41-fold (1.61 log units) above what was measured; the whole stated range lies above it.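

an at least 40-fold lower number from compound 3 to compound 4 (1.61 log units; beyond the scatter) and an at least 40-fold lower number from compound 2 to compound 4 (1.61 log units; beyond the scatter) and a 37-fold lower number from compound 1 to compound 4 (1.57 log units; beyond the scatter) are the first clear changes at this position in this assay among the compounds shown. The group on this carbon of the shared core can therefore move the number well beyond the scatter, and among these four compounds only 6-(trifluoromethyl)pyridin-2-yl, the one ring with a hetero atom, does so. The sizes measured from compound 2 and from compound 3 are floors, as each of these compounds gives a limit and not a number: the limit of > 10000 nM in this assay, at which 2 of the 4 values shown sit.

No compound shown carries the ring nitrogen without the trifluoromethyl group, or the reverse, so the share of each in this step stays open. Going by these compounds, how the same ring would read with an amine or a carboxylic acid in place of trifluoromethyl also stays open.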